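Trifluoromethyl for methyl on an inactive oxadiazole series

This account rests on a few compounds, and the source may have more. Where it says the series, first, only, none or still open, it means among the compounds named here.

Compound 1 `Cc1cc(CCC(=O)O)ccc1-c1noc(-c2ccc(OC(C)C)c(C#N)c2)n1`: in a functional assay on CHO cells with sphingosine 1-phosphate receptor 4 (Homo sapiens) as the target, read by GTPgammaS binding (on this read-out lower numbers stand for an effect already at smaller amounts and higher numbers for an effect only at larger amounts of compound), compound 1 gives only a limit of the assay, > 10000 nM.
Compound 2 `Cc1cc(CCC(=O)O)ccc1-c1noc(-c2ccc(OC(C)C(F)(F)F)c(C#N)c2)n1`: compound 2 likewise gives only a limit, > 10000 nM.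
Compound 3 `Cc1cc(CCC(=O)O)ccc1-c1noc(-c2cnc(OC(C)C)c(Cl)c2)n1`: compound 3 also gives only a limit, > 10000 nM.

From compound 1 to compound 2 the change is trifluoromethyl in place of methyl on a saturated chain carbon bound to an oxygen on an aromatic ring and a saturated chain carbon. The step that the two limits leave unreadable from compound 1 to compound 2 cannot be read, because of the limit of > 10000 nM in this assay, at which 3 of the 3 values shown sit. The difference between the core of compound 1 and the core of compound 3 is not broken down here.

Compound 4 `Cc1cc(CCC(=O)O)ccc1-c1noc(-c2cnc(OC(C)C(F)(F)F)c(Cl)c2)n1` differs from compound 3 by trifluoromethyl in place of methyl on a saturated chain carbon bound to an oxygen on an aromatic ring and a saturated chain carbon, the same change at the same place. Compound 4 is expected to stay at the limit, with a step that the limit leaves unreadable from compound 3 to compound 4, because the limit of > 10000 nM in this assay, at which 3 of the 3 values shown sit, gives no sign that this change brings any compound into the measurable range. The estimate for compound 4 is 20000 nM, between 8000 nM and 60000 nM.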

Compound 4, half-maximal effective concentration: > 10000 nM
Compound 4 was reported as a limit (the forecaster's own chance of this, stated with the estimate: 90%); the middle value does not contradict the limit.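

The step from compound 3 to compound 4 cannot be read, because both results are limits of the assay, not numbers: the limit of > 10000 nM in this assay, at which 4 of the 4 values shown sit.

The compounds shown leave open whether trifluoromethyl in place of methyl changes the effect at all.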